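The source may report more compounds than this note shows. Statements on the series, on what has been measured and on what is new or still open speak of the compounds shown alone.

Compound 2 `O=C(NCCCNc1cc(-c2cn(-c3ccccc3)nc2-c2cccc(O)c2)ccn1)c1ccccc1` is one of two compounds already measured in a functional assay on SNB-75 cells (Homo sapiens) for inhibition; on this read-out lower numbers stand for stronger inhibition of growth and higher numbers for weaker inhibition of growth. In this assay compound 2 gives 46900 nM, the lowest of the two numbers shown. Within the data shown here, compound 1 `COc1cccc(-c2nn(-c3ccccc3)cc2-c2ccnc(NCCNC(=O)Nc3cccc(C(F)(F)F)c3)c2)c1` differs from it in several places at once, and in this assay compound 1 gives 100000 nM, a gap that lies beyond the usual scatter; no single step links these two compounds, so only their two values can be compared. Compound 3 `O=C(NCCCNc1cc(-c2cn(-c3ccccc3)nc2-c2cccc(O)c2)ccn1)c1ccc(F)cc1` has not yet been measured. It differs from compound 2 by fluoro in place of hydrogen on an aromatic carbon, within the benzoyl part of the molecule. Nothing already measured shows what such a change does here, so the step is expected to be small: the estimated change a 1.2-fold lower number from compound 2 to compound 3 (0.07 log units; within the scatter) is expected to lie within the scatter. Compound 3 is therefore expected to give about 40000 nM in this assay, with a likely range from 15000 nM to 100000 nM.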

Compound 3, concentration for total growth inhibition: 12500 nM
For compound 3 the middle estimate is 3.2-fold (0.51 log units) above the measured one; the whole stated range lies above it.
By their numbers in this assay, from the lowest: compound 3; then compound 2; then compound 1.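

Changing phenyl to 4-fluorophenyl, with the fluoro para to a large group, gives in this assay a 3.8-fold lower number from compound 2 to compound 3 (0.57 log units; beyond the scatter), the first single-place step available here. This position is therefore not indifferent: one added heavy atom, with the rest of the molecule unchanged, is enough to strengthen growth inhibition, something the earlier pair, which differs in several places at once, could not show. Nothing available explains why this step has this size.

With a single replacement shown, it stays open whether chloro, methyl or methoxy in the same place would strengthen inhibition further, leave it unchanged or weaken it. On these data alone, it also stays open whether fluoro would have the same effect elsewhere on this ring or in molecules with a different chain.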